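The compounds below may be only part of what the source reports. "The series", "measured", "known", "first", "only" and "open" are said of these compounds alone.

Measured in a functional assay on HeLa cells (Homo sapiens) for inhibition; on this read-out lower numbers stand for stronger inhibition and higher numbers for weaker inhibition:
compound 1 `Oc1cccc(-c2cc(-c3cccc(F)c3)cc(-c3cccc(O)c3)n2)c1`: 1400 nM
compound 2 `Oc1ccc(-c2cc(-c3cccc(F)c3)cc(-c3cccc(O)c3)n2)cc1`: 14200 nM
compound 3 `Oc1cccc(-c2cc(-c3ccccc3C(F)(F)F)cc(-c3cccc(O)c3)n2)c1`: 15200 nM

Compound 1 gives the lowest number of the three in this assay. Its nearest neighbour is compound 2, with a 10-fold higher number from compound 1 to compound 2 (1.01 log units; beyond the scatter), and the step to compound 3 is an 11-fold higher number from compound 1 to compound 3 (1.04 log units; beyond the scatter); both are beyond the scatter, so compound 1 stands clearly apart as the strongest inhibitor of the three.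

Compound 4 `Oc1cccc(-c2cc(-c3cccc(OC(F)(F)F)c3)cc(-c3cccc(O)c3)n2)c1` is not yet measured. Relative to compound 1 the change is trifluoromethoxy in place of fluoro on an aromatic carbon; the trifluoromethoxy sits on an aromatic carbon of a six-membered aromatic ring of carbon only, meta to a large group, where the fluoro sat before.

Within the data shown here, only one measured step touches this ring: the move to compound 3, an 11-fold higher number from compound 1 to compound 3 (1.04 log units; beyond the scatter), which swapped the fluoro for a trifluoromethyl and also moved it. The step to compound 2 concerns a different ring and does not bear on this change. With one relevant step, itself large, a weakening beyond the scatter is expected for compound 4, but smaller than an 11-fold higher number from compound 1 to compound 3 (1.04 log units; beyond the scatter), since the substituent keeps its place.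

Compound 4 is therefore estimated at 3500 nM, range 1200 nM to 12000 nM, an expected step of a 2.5-fold higher number from compound 1 to compound 4 (0.40 log units; beyond the scatter).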

Compound 4, half-maximal inhibitory concentration: > 50000 nM
Compound 4: only a limit was reported (the forecaster's own chance of this, stated with the estimate: 5%); middle value at least 14-fold (1.15 log units) from the limit.
By their numbers in this assay, from the lowest: compound 1; then compounds 2 and 3 (each within the scatter of the next). At a limit, above all of these: compound 4.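

At the place meta to a large group, on the six-membered aromatic ring of carbon only, trifluoromethoxy in place of fluoro gives an at least 35-fold higher number from compound 1 to compound 4 (1.55 log units; beyond the scatter) in this assay, so the inhibition seen with fluoro at this place is not retained with this larger group. The reported value for compound 4 is a limit of the assay, not a number: the limit of > 50000 nM in this assay, at which 1 of the 4 values shown sits. The earlier change at this ring, an 11-fold higher number from compound 1 to compound 3 (1.04 log units; beyond the scatter), altered both the group and its place, whereas this step alters the group alone and shows that a loss beyond the scatter occurs with the place kept.

With only fluoro and trifluoromethoxy at this place, the compounds shown cannot separate the effect of the added heavy atoms from that of the oxygen that links the group to the ring. From the compounds shown here alone, a methoxy, a chloro or a trifluoromethyl at this same place would bear on that question, and the response to an amine or a carboxylic acid here remains open as well.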